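Swapping Piperidine Back for Methylpiperazine: An Expected Gain

A few compounds are considered here, and "the series" means these few. Any claim that something is new, unique, unknown or untested is made for them only; others in the source may bear on it.

Compound 1, `CCN1CCN(c2cc(C)c3cc(NC(=O)c4ccc(OC)cc4)ccc3n2)CC1`: 9000 nM
Compound 2, `Cc1cc(N2CCN(C(C)C)CC2)nc2ccc(NC(=O)c3ccc(Cl)c(Cl)c3)cc12`: 6680 nM
Compound 3, `Cc1cc(N2CCCCC2)nc2ccc(NC(=O)c3ccc(Cl)c(Cl)c3)cc12`: 42500 nM

In a functional assay on SK-BR-3 cells (Homo sapiens) for antiproliferative activity, read by MTT assay, with a stated time of 72 h (a lower number here means a stronger inhibitor, a higher number a weaker inhibitor), compound 3 stands highest of the three numbers, with compound 1 and compound 2 both sitting beyond the scatter below it. Compound 4, `Cc1cc(N2CCN(C)CC2)nc2ccc(NC(=O)c3ccc(Cl)c(Cl)c3)cc12`, differs from compound 3 by 4-methylpiperazin-1-yl in place of piperidin-1-yl on an aromatic carbon. Among the compounds with values here, the one measured step that bears on this change is a 6.4-fold higher number from compound 2 to compound 3 (0.80 log units; beyond the scatter), which ran the opposite way, a piperazine-bearing group giving way to piperidin-1-yl. Reversing that exchange, compound 4 is expected to come in lower than compound 3 by roughly the same margin, a 7.7-fold lower number from compound 3 to compound 4 (0.89 log units; beyond the scatter). The estimate for compound 4 is therefore 5500 nM, with a range from 2000 nM to 14000 nM.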

Compound 4, half-maximal inhibitory concentration: 6320 nM
The estimate for compound 4 lay 1.1-fold (0.06 log units) below the measured number; the range from low to high includes it.
By their numbers in this assay, from the lowest: compounds 4, 2 and 1 (each within the scatter of the next); then compound 3.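

The step of a 6.7-fold lower number from compound 3 to compound 4 (0.83 log units; beyond the scatter) in this assay shows that the lower number seen with a piperazine at this place, next to the ring nitrogen, does not depend on the isopropyl group, since 4-methylpiperazin-1-yl also gives it. Methyl and isopropyl on the ring nitrogen cannot be told apart here, with a 1.1-fold lower number from compound 2 to compound 4 (0.02 log units; within the scatter) lying within the scatter. Still open, going by these compounds, is whether an unsubstituted piperazine or a benzyl group on that nitrogen would fit the same picture, and where morpholine would stand against piperidine. Nothing available explains why the piperazines give lower numbers than the piperidine.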